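Triazole ester series: nitro for fluoro on the phenyl

The source may report more compounds than this note shows. Statements on the series, on what has been measured and on what is new or still open speak of the compounds shown alone.

Measured compounds in a functional assay on DU-145 cells (Homo sapiens) for antiproliferative activity, read by MTT assay, with a stated time of 48 h; on this read-out lower numbers stand for stronger inhibition and higher numbers for weaker inhibition:
- compound 1 `C/C(=C\CC/C(C)=C/CC[C@@H]1[C@@]2(C)CCC(=O)C(C)(C)[C@H]2CC[C@@]1(C)O)CC/C=C(\C)C(=O)OCc1cn(-c2cccc(C(F)(F)F)c2)nn1` gives > 150000 nM, a limit of the assay.
- compound 2 `C/C(=C\CC/C(C)=C/CC[C@@H]1[C@@]2(C)CCC(=O)C(C)(C)[C@H]2CC[C@@]1(C)O)CC/C=C(\C)C(=O)OCc1cn(-c2ccccc2F)nn1` gives > 150000 nM, a limit of the assay.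
- compound 3 `C/C(=C\CC/C(C)=C/CC[C@@H]1[C@@]2(C)CCC(=O)C(C)(C)[C@H]2CC[C@@]1(C)O)CC/C=C(\C)C(=O)OCc1cn(-c2cccc(F)c2)nn1` gives > 150000 nM, a limit of the assay.

Compound 3 stands at the same limit as the other two members; no number separates them. All three values sit at the limit of > 150000 nM in this assay, at which 3 of the 3 values shown sit, so the steps a step that the two limits leave unreadable from compound 1 to compound 2, a step that the two limits leave unreadable from compound 1 to compound 3 and a step that the two limits leave unreadable from compound 2 to compound 3 carry no readable size, whichever phenyl substituent is changed on the aromatic nitrogen.

Compound 4 `C/C(=C\CC/C(C)=C/CC[C@@H]1[C@@]2(C)CCC(=O)C(C)(C)[C@H]2CC[C@@]1(C)O)CC/C=C(\C)C(=O)OCc1cn(-c2cccc([N+](=O)[O-])c2)nn1` is still to be measured in this assay. Its difference from compound 3 is nitro in place of fluoro on an aromatic carbon. For the measured compounds named here, of the measured steps, those from compound 1 and compound 2 into compound 3 are the only ones that touch the same phenyl group, and both are unreadable between limits; no measured step shows any change on this ring moving the read-out off the limit.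

For compound 4 the estimate is therefore 200000 nM, with a range from 50000 nM to 600000 nM, and most likely a limit rather than a number. The implied step that the limit leaves unreadable from compound 3 to compound 4 is an expectation only, since the measured steps give no size to anchor it.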

Compound 4, half-maximal inhibitory concentration: > 150000 nM
Compound 4 ended at the assay's limit; the forecaster's own chance of this, stated with the estimate: 85%; the middle value does not contradict the limit.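

Compound 4 sits at the same limit as compound 1, compound 2 and compound 3, so no step among these four compounds can be read: the limit of > 150000 nM in this assay, at which 4 of the 4 values shown sit.

Whether any phenyl substituent shown moves the antiproliferative read-out off this limit, and by how much, remains open.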